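The compounds below may be only part of what the source reports. "The series", "measured", "known", "first", "only" and "open" are said of these compounds alone.

Among the compounds with values here, compound 2, `Nc1nc(N)c(CCCN(Cc2ccc(NC(CCC(=O)O)C(=O)O)cc2)c2ccc([N+](=O)[O-])c(F)c2[N+](=O)[O-])c(O)n1`, is the only member of this set with a number rather than a limit: in a functional assay on CCRF-CEM cells (Homo sapiens) for cytotoxicity, in the absence of a further agent (on this read-out lower numbers stand for stronger inhibition and higher numbers for weaker inhibition), compound 2 gives 36000 nM. Compound 1, `Nc1nc(N)c(CCCN(Cc2ccc(NC(CCC(=O)O)C(=O)O)cc2)c2cc(F)cc(F)c2[N+](=O)[O-])c(O)n1`, sits at a limit in this assay, where compound 1 gives > 100000 nM; this is the limit of > 100000 nM in this assay, at which 1 of the 2 values shown sits.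

Compound 3, `Nc1nc(N)c(CCCN(Cc2ccc(NC(CCC(=O)O)C(=O)O)cc2)c2ccc([N+](=O)[O-])c(F)c2F)c(O)n1`, is not yet measured. It differs from compound 2 by fluoro in place of nitro on an aromatic carbon. Within the data shown here, no step between measured compounds in this set covers such a change, so no direction can be taken from the data. The step from compound 2 to compound 3 is expected to be a 1.7-fold higher number from compound 2 to compound 3 (0.22 log units; within the scatter), a mild weakening of cytotoxicity. For compound 3 the expected value in this assay is 60000 nM, within 20000 nM to 200000 nM.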

Compound 3, half-maximal inhibitory concentration: > 100000 nM
Compound 3 gave a limit, no number (the forecaster's own chance of this, stated with the estimate: 35%); at least 1.6-fold (0.22 log units) between middle value and limit.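

In this assay, fluoro in place of nitro at the position ortho to a fluoro group and meta to a nitro group gives an at least 2.7-fold higher number from compound 2 to compound 3 (0.44 log units; beyond the scatter) and so marks this position as the first in the series with a readable change. From the compounds shown here alone, compound 3 gives a limit, not a number, so the full size of this step stays unknown. The step between compound 1 and compound 3 cannot be read, as both values are limits: the limit of > 100000 nM in this assay, at which 2 of the 3 values shown sit.

Going by these compounds, whether an amine or a nitrile at this position would keep the value of compound 2 remains open. Also open, on these data alone, is whether the nitro group itself matters here, or whether any group larger than fluoro would serve.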